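A few compounds are considered here, and "the series" means these few. Any claim that something is new, unique, unknown or untested is made for them only; others in the source may bear on it.

Measured compounds:
- compound 1, `CC(=O)N1CC2(CC(NC(=O)c3cc(-c4ccc(F)cc4)no3)C2)C1`, 79% in an ADME assay on microsomes from liver (Macaca mulatta) for metabolic stability, with a stated time of 0.5 h, tested at 0.5 mg/mL; a lower number here means that less of the compound is left, a higher number that more of the compound is left
- compound 2, `CN(C)C(=O)CNC(=O)c1cc(-c2ccc(F)cc2)no1`, 11%

Of the compounds shown here, two have been measured so far, and the two numbers lie far apart. In this assay compound 1 gives 79%, the higher of the two numbers, while compound 2 gives 11%, a gap that is well beyond the usual scatter. The two structures share the same central piece bearing the 4-fluorophenyl group, and they differ only in what hangs on the other side of the amide.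

Compound 3, `CC(=O)N1CC2(CC(NC(=O)c3cc(-c4ccccc4)no3)C2)C1`, has not been measured. It keeps everything of compound 1 except one detail: hydrogen in place of fluoro on an aromatic carbon. Within the data shown here, the structural change is small, a single fluorine giving way to a hydrogen, and no step between measured compounds of this kind is available for comparison.

With so little to go on, a modest effect is expected. The step of a number 9 percentage points lower from compound 1 to compound 3 (within the scatter) is expected to be slightly downward, likely no further than the scatter of the assay. Compound 3 is therefore expected to give about 70%, within a range from 50% to 85%.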

Compound 3, percent of the compound remaining in the Macaca mulatta assay: 64%
Compound 3: middle estimate off by 6 percentage points, on the high side; the range from low to high includes it.
By their numbers in the Macaca mulatta assay, from the lowest: compound 2; then compound 3; then compound 1.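

Among these compounds, in the Macaca mulatta assay, the change from 4-fluorophenyl to phenyl gives a number 15 percentage points lower from compound 1 to compound 3 (beyond the scatter), the first step here in which only one place differs, and it shows that this single atom on the aromatic ring, para to a large group, can move the read-out beyond the usual scatter, though only modestly. In a physicochemical assay for solubility, at pH 6.8 (on this read-out lower numbers stand for lower solubility and higher numbers for higher solubility), compound 1 gives > 100 ug/mL, which is a limit of the assay and not a number. In the physicochemical assay compound 3 gives > 100 ug/mL, also a limit, so the step on this read-out cannot be read: the limit of > 100 ug/mL in the physicochemical assay, at which 2 of the 2 values shown sit.

Still open, on these data alone, is what a chlorine, a methoxy group or a nitrile in the same place on the ring would do in the Macaca mulatta assay, and whether any of them would leave more of the compound than the fluoro does. Among the compounds shown here, also open is whether the change from 4-fluorophenyl to phenyl would give a step of similar size and the same direction in a compound whose amide carries a different group, such as an amine-bearing chain, in place of the one in compound 1.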